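This account rests on a few compounds, and the source may have more. Where it says the series, first, only, none or still open, it means among the compounds named here.

Compound 1 `O=C1OC[C@H](Cc2ccccc2)[C@H]1Cc1ccccc1C(F)(F)F` gives 37000 nM
Compound 2 `Cc1ccc(C[C@H]2C(=O)OC[C@@H]2Cc2ccccc2)cc1` gives 44000 nM
Compound 3 `COc1ccccc1C[C@H]1COC(=O)[C@@H]1Cc1ccc(Cl)c(Cl)c1` gives 14000 nM

In a functional assay on HL-60 cells (Homo sapiens) for cytotoxicity, read by WST assay, with a stated time of 48 h (a higher number here means that more compound is needed for the effect, a lower number that less compound is needed), compound 3 has the lowest number of these three, while compound 1 and compound 2 both stand higher, each beyond the usual scatter. Compound 4 `COc1cccc(C[C@H]2COC(=O)[C@@H]2Cc2ccc(Cl)c(Cl)c2)c1` has the same atoms as compound 3, with 3-methoxyphenyl in place of 2-methoxyphenyl on a saturated chain carbon bound to a saturated ring carbon. Going by the values given here, no measured pair here shows a change of this kind. The expected step of a 1.1-fold higher number from compound 3 to compound 4 (0.06 log units; within the scatter) is small, with no firm direction and nothing beyond the scatter. This expectation rests on compound 3 at 14000 nM as the closest measured relative. In this assay the estimated value for compound 4 is 16000 nM with an expected range from 7000 nM to 35000 nM for this measurement.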

Compound 4, half-maximal effective concentration: 34000 nM
Estimate against measurement, compound 4: 2.1-fold (0.33 log units) below; the range from low to high includes it.
By their numbers in this assay, from the lowest: compound 3; then compounds 4, 1 and 2 (each within the scatter of the next).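

Moving the methoxy group on the same atoms gives a 2.4-fold higher number from compound 3 to compound 4 (0.39 log units; beyond the scatter) in this assay on this saturated chain carbon bound to a saturated ring carbon. Going by these compounds alone, this is the first pair that differs in one place, so 2-methoxyphenyl and 3-methoxyphenyl are seen not to be interchangeable here, although neither compound stands out strongly. Nothing measured here gives a reason for this step. As far as these compounds go, it remains open whether an amine or a carboxylic acid in place of the methoxy group would keep this cytotoxic effect. A single pair also cannot show whether the same change would give a similar step with other groups on the rest of the core.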